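A few compounds are considered here, and "the series" means these few. Any claim that something is new, unique, unknown or untested is made for them only; others in the source may bear on it.

Of the compounds shown here, three have so far been measured in a functional assay on the whole organism (blood) with Rattus norvegicus as the target, with stated times of 24 h and 1 h, at a dose of 5 mg/kg by the intraperitoneal route; a higher number here means a stronger effect of the compound at the dose given, a lower number a weaker effect. Compound 1 `O=C(NC1CCCCC1)NS(=O)(=O)N1CCC(CCNC(=O)C(F)(F)F)CC1` gives 13%. Compound 2 `O=C(NC[C@@H]1C[C@@H]2C=C[C@@H]1C2)NS(=O)(=O)N1CCC(CCNC(=O)C(F)(F)F)CC1` gives 22%, and compound 3 `O=C(NC1CCCCC1)NS(=O)(=O)N1CCC(CCNC(=O)c2cc(Cl)cc3cccnc23)CC1` gives 52%. Among these three numbers compound 2 stands second highest: its nearest neighbour is compound 1, with a number 9 percentage points higher from compound 1 to compound 2 (within the scatter), and its furthest is compound 3, whose number lies higher by more than the scatter.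

Compound 4 `O=C(NC[C@@H]1C[C@@H]2C=C[C@@H]1C2)NS(=O)(=O)N1CCC(CCNC(=O)c2cccc3c2OCCO3)CC1` has not yet been measured. It differs from compound 2 in a single place: 2,3-dihydro-1,4-benzodioxin-5-yl in place of trifluoromethyl on a carbonyl carbon. Within the data shown here, one measured step bears on this change. It also replaces trifluoromethyl on that same carbonyl carbon, there with 6-chloroquinolin-8-yl: a number 39 percentage points higher from compound 1 to compound 3 (beyond the scatter). Among the measured compounds shown here, the group entering in compound 4 is a different one, so the size of that step cannot simply be carried over, but the only comparable evidence points upward.

A rise in this assay is therefore expected for compound 4, smaller and less certain than the measured one, and the step estimated is a number 18 percentage points higher from compound 2 to compound 4 (beyond the scatter). Compound 4 is expected to give 40%, with a range from 15% to 65%.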

Compound 4, a percentage reported as activity, at one dose (the size of the read-out at that dose, not a potency): 11%
For compound 4 the middle estimate is 29 percentage points above the measured one; measured number below the stated range.
By their numbers in this assay, from the lowest: compounds 4, 1 and 2 (each within the scatter of the next, the first and the last beyond it); then compound 3.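

In this assay, replacing trifluoromethyl on this carbonyl carbon does not raise the number as a rule: 2,3-dihydro-1,4-benzodioxin-5-yl gives a number 11 percentage points lower from compound 2 to compound 4 (beyond the scatter), against a number 39 percentage points higher from compound 1 to compound 3 (beyond the scatter) with 6-chloroquinolin-8-yl. The position can therefore move the read-out in either direction, and what matters is not only that trifluoromethyl leaves, although the two steps start from compounds that differ at another place, so the entering group and that other place cannot yet be separated. Nothing measured here accounts for the fall seen with the 2,3-dihydro-1,4-benzodioxin-5-yl group.

Still open, as far as these compounds go, is whether 6-chloroquinolin-8-yl would raise the number when it replaces trifluoromethyl in compound 2, and whether 2,3-dihydro-1,4-benzodioxin-5-yl would lower it when it replaces trifluoromethyl in compound 1. Also open, from the compounds shown here alone, is how simpler groups on the same carbonyl carbon, such as a plain phenyl ring or a methyl group, would compare, which could help show which part of each entering group goes with the rise or the fall.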